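A few compounds are considered here, and "the series" means these few. Any claim that something is new, unique, unknown or untested is made for them only; others in the source may bear on it.

In an ADME assay on CCRF-CEM cells (Homo sapiens) for cytotoxicity, with a stated time of 4 days (on this read-out higher numbers stand for lower toxicity in this test and lower numbers for higher toxicity in this test), the measurements so far are:

- Compound 1 `Cc1cn([C@@H]2O[C@H](CO[Si](C)(C)C(C)(C)C)[C@@]3(OS(=O)(=O)C=C3N)[C@H]2O[Si](C)(C)C(C)(C)C)c(=O)n(C(=O)c2ccccc2)c1=O`: 54000 nM
- Compound 2 `Cc1cn([C@@H]2O[C@H](CO[Si](C)(C)C(C)(C)C)[C@@]3(OS(=O)(=O)C=C3N)[C@H]2O[Si](C)(C)C(C)(C)C)c(=O)n(C(=O)CCCBr)c1=O`: 11000 nM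

Compound 2, at 11000 nM, has the lower of these two numbers. Compound 3 `Cc1cn([C@@H]2O[C@H](CO[Si](C)(C)C(C)(C)C)[C@@]3(OS(=O)(=O)C=C3N)[C@H]2O[Si](C)(C)C(C)(C)C)c(=O)n(C(=O)C2CC2)c1=O` differs from it by cyclopropyl in place of 3-bromopropyl on a carbonyl carbon, with cyclopropyl in place of 3-bromopropyl on a carbonyl carbon. Going by the values given here, one measured step bears on this change: a 4.9-fold lower number from compound 1 to compound 2 (0.69 log units; beyond the scatter), a modest step at the same place. Like compound 1, at 54000 nM, compound 3 carries a ring there, so a similar or smaller step toward a higher number is expected in this assay. The expected step is a 2.3-fold higher number from compound 2 to compound 3 (0.36 log units; beyond the scatter). The estimate for compound 3 is 25000 nM, with a range of 9000 nM to 70000 nM.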

Compound 3, half-maximal cytotoxic concentration: 11000 nM
Compound 3: middle estimate off by 2.3-fold (0.36 log units), on the high side; the range from low to high includes it.
By their numbers in this assay, from the lowest: compounds 2 and 3 (each within the scatter of the next); then compound 1.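

In this assay, the change to cyclopropyl gives no change at the digits printed from compound 2 to compound 3 (within the scatter), so the bromine and open chain of 3-bromopropyl are not needed at this carbonyl carbon for the number seen with compound 2. The step of a 4.9-fold lower number from compound 1 to compound 3 (0.69 log units; beyond the scatter) shows that a ring there does not by itself keep the number at the level of compound 1, since the three-membered ring of compound 3 does not match phenyl. Nothing available explains these numbers. From the compounds shown here alone, whether a plain butyl chain, a cyclohexyl ring or a pyridine ring would track compound 1 or compound 3 stays open.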